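The source may report more compounds than this note shows. Statements on the series, on what has been measured and on what is new or still open speak of the compounds shown alone.

Measured so far:
compound 1 `C=C(C)[C@@H]1CC=C(C)/C(=N/NC(=O)Nc2nnc(-c3ccccc3)o2)C1`: 300 mg/kg
compound 2 `C=C(C)[C@@H]1CC=C(C)/C(=N/NC(=O)Nc2nnc(-c3ccc([N+](=O)[O-])cc3)o2)C1`: 300 mg/kg

In a functional assay on the whole organism (strain Swiss albino) with Mus musculus as the target, with a stated time of 4 h (on this read-out lower numbers stand for an effect already at smaller amounts and higher numbers for an effect only at larger amounts of compound), compound 1 gives 300 mg/kg and stands level with compound 2 at the digits shown; the one step, no change at the digits printed from compound 1 to compound 2 (within the scatter), lies within the scatter. Compound 3 `C=C(C)[C@@H]1CC=C(C)/C(=N/NC(=O)Nc2nnc(-c3ccc(O)cc3)o2)C1` differs from compound 1 by hydroxy in place of hydrogen on an aromatic carbon. Among the compounds with values here, only that step bears on it, and it showed no movement, so nothing beyond the scatter is expected in this assay. For compound 3 the expected step is no change at the digits printed from compound 1 to compound 3 (within the scatter), and the expected value is 300 mg/kg with a range from 150 mg/kg to 600 mg/kg.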

Compound 3, minimum effective dose: 300 mg/kg
Compound 3: middle estimate and measured number agree at the digits printed, and the stated range covers the measured number.
By their numbers in this assay, from the lowest: compounds 1, 2 and 3 (each within the scatter of the next).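

In this assay the 4-hydroxyphenyl of compound 3 reads level with the phenyl of compound 1 (no change at the digits printed from compound 1 to compound 3 (within the scatter)) and with the nitro-bearing ring of compound 2 (no change at the digits printed from compound 2 to compound 3 (within the scatter)). The aromatic position para to a large group has now carried hydrogen, nitro and hydroxy without any separation on this read-out, where the earlier pair showed only hydrogen and nitro.

On these data alone, whether an amine, a carboxylic acid or a longer chain at this position would move the dose remains open, as does the effect of changes elsewhere on the core. No supporting data bear on why these three compounds read level.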